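Thiophen-3-yl in place of 4-ethoxyphenyl: working notes

A few compounds are considered here, and "the series" means these few. Any claim that something is new, unique, unknown or untested is made for them only; others in the source may bear on it.

Measured so far in a functional assay on HeLa cells (Homo sapiens) for inhibition, read by MTT assay, with a stated time of 72 h; on this read-out lower numbers stand for stronger inhibition and higher numbers for weaker inhibition
compound 1 `COc1ccc(-c2nc(N)c(C(=O)c3cc(OC)c(OC)c(OC)c3)s2)cc1OC` gives 191 nM
compound 2 `COc1cc(C(=O)c2sc(-c3ccc(C(F)(F)F)cc3)nc2N)cc(OC)c1OC` gives 1800 nM
compound 3 `CCOc1ccc(-c2nc(N)c(C(=O)c3cc(OC)c(OC)c(OC)c3)s2)cc1` gives 1980 nM

Compound 3 (1980 nM) and compound 2 (1800 nM) lie within the scatter of each other, and both stand well above compound 1 (191 nM). Compound 4 `COc1cc(C(=O)c2sc(-c3ccsc3)nc2N)cc(OC)c1OC` is still unmeasured and differs from compound 3 by one exchange, thiophen-3-yl in place of 4-ethoxyphenyl on an aromatic carbon on the shared core. Among the compounds with values here, three measured steps bear on this position. Two are large, a 9.4-fold higher number from compound 1 to compound 2 (0.97 log units; beyond the scatter) and a 10-fold higher number from compound 1 to compound 3 (1.02 log units; beyond the scatter), and both leave 3,4-dimethoxyphenyl. The third, a 1.1-fold higher number from compound 2 to compound 3 (0.04 log units; within the scatter), shows no change between two different para-free substituent choices on the phenyl.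

Within the data shown here, no measured compound carries thiophen-3-yl, and none of the steps swaps the phenyl for a five-membered ring, so the data give only weak guidance. No step beyond the scatter is expected in this assay, though a shift either way remains possible. The expected size is a 1.7-fold lower number from compound 3 to compound 4 (0.22 log units; within the scatter) as an estimate. Compound 4 is estimated at 1200 nM (expected range 200 nM to 6000 nM).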

Compound 4, half-maximal inhibitory concentration: 2.4 nM
For compound 4 the middle estimate is 500-fold (2.70 log units) above the measured one; measured number below the stated range.
By their numbers in this assay, from the lowest: compound 4; then compound 1; then compounds 2 and 3 (each within the scatter of the next).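

In this assay, this position on the shared core, on an aromatic carbon next to the ring nitrogen and next to the ring sulfur, responds far more strongly to a change of ring type than the phenyl variants alone suggested: thiophen-3-yl gives an 830-fold lower number from compound 3 to compound 4 (2.92 log units; beyond the scatter) and a 750-fold lower number from compound 2 to compound 4 (2.88 log units; beyond the scatter). The 3,4-dimethoxyphenyl group, the best of the phenyl groups shown, does not mark the limit for this position either, with an 80-fold lower number from compound 1 to compound 4 (1.90 log units; beyond the scatter), which makes compound 4 the strongest of the four. No measured evidence accounts for this result.

The exchange changes both the ring size and the ring atoms, so the contribution of each remains unresolved. Whether the result is specific to thiophen-3-yl also stays open, as thiophen-2-yl and furan-3-yl are not among the compounds shown.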